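The compounds below may be only part of what the source reports. "The series", "measured", "known", "first", "only" and "open" are said of these compounds alone.

Working notes on the series.

The shared core carries a pentafluorophenylsulfonyl azetidine amide on an aniline-type nitrogen that also bears a cyclohexyl-substituted heteroaryl methyl arm; the compounds differ in the aryl ring on that nitrogen. In a functional assay on MDA-MB-231 cells (Homo sapiens) for antiproliferative activity, with a stated time of 72 h (on this read-out lower numbers stand for an effect already at smaller amounts and higher numbers for an effect only at larger amounts of compound), compound 1 `COC(=O)c1ccc(N(Cc2cnc(C3CCCCC3)cn2)C(=O)[C@H]2CCN2S(=O)(=O)c2c(F)c(F)c(F)c(F)c2F)cc1O` gives 1600 nM. Compound 2 `CONC(=O)c1ccc(N(Cc2ccc(C3CCCCC3)cn2)C(=O)[C@H]2CCN2S(=O)(=O)c2c(F)c(F)c(F)c(F)c2F)cc1O` gives 6700 nM in this assay and so stands highest of the two numbers reported, with the gap to compound 1 lying beyond the scatter of the read-out. Compound 3 `CNC(=O)c1ccc(N(Cc2cnc(C3CCCCC3)cn2)C(=O)[C@H]2CCN2S(=O)(=O)c2c(F)c(F)c(F)c(F)c2F)cc1O` is recorded as "not determined" (no result reported) in this assay, so no number is at hand for it.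

Compound 4 `O=C1NC(=O)c2cc(N(Cc3ccc(C4CCCCC4)cn3)C(=O)[C@H]3CCN3S(=O)(=O)c3c(F)c(F)c(F)c(F)c3F)ccc21` has not yet been run. Relative to compound 2 the change is a group of 11 heavy atoms (8 carbon, 1 nitrogen, 2 oxygen; one five-membered non-aromatic ring with 1 hetero atom, one six-membered aromatic ring of carbon only) in place of a group of 12 heavy atoms (8 carbon, 1 nitrogen, 3 oxygen; one six-membered aromatic ring of carbon only), on an amide-type nitrogen. Within the data shown here, no measured pair isolates this change, and the only two numbers at hand do not tell how the aryl portion is tolerated when its open amide and hydroxyl are tied into a ring. In this assay the step from compound 2 to compound 4 is therefore expected to be small, a 1.5-fold lower number from compound 2 to compound 4 (0.17 log units; within the scatter), with no clear direction beyond the scatter. On that basis compound 4 is estimated to give 4500 nM in this assay, with a range from 1200 nM to 20000 nM.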

Compound 4, half-maximal effective concentration: 1700 nM
The estimate for compound 4 lay 2.6-fold (0.42 log units) above the measured number; measured number inside the range.
By their numbers in this assay, from the lowest: compounds 1 and 4 (each within the scatter of the next); then compound 2.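

In this assay, putting the ring-closed group on the amide-type nitrogen in place of 3-hydroxy-4-(methoxycarbamoyl)phenyl gives a 3.9-fold lower number from compound 2 to compound 4 (0.60 log units; beyond the scatter), so this place does not require the open group and accepts a second, five-membered non-aromatic ring. Among these compounds, this is the first step that isolates a change at this place: compounds 1 and 2 differ in more than one place, and compound 3 has no number. The step alters the hydroxyl, the methoxy group and the ring count together, and no measurement at hand shows which of these matters or gives a reason for the shift.

A simple carboxylic acid or primary amide in place of the methoxycarbamoyl group, with the hydroxyl kept or removed, would help to separate ring closure from the loss of those groups. Also open, from the compounds shown here alone, is whether a methyl group on the ring nitrogen of the closed group is tolerated, and whether the closed group gives a similar step on the heteroaryl methyl arm of compound 1.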